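The compounds below may be only part of what the source reports. "The series", "measured", "known", "first", "only" and "open" are said of these compounds alone.

compound 1 `CS(=O)(=O)Nc1ccc2c(c1)S(=O)(=O)N=C(C1=C(O)[C@@H]3[C@H]4CC[C@H](C4)[C@@H]3N(Cc3ccc(F)c(F)c3F)C1=O)N2`: 100%
compound 2 `CS(=O)(=O)Nc1ccc2c(c1)S(=O)(=O)N=C(C1=C(O)[C@@H]3[C@@H]4CC[C@@H](C4)[C@@H]3N(Cc3ccccc3)C1=O)N2`: 90%
compound 3 `CS(=O)(=O)Nc1ccc2c(c1)S(=O)(=O)N=C(C1=C(O)[C@@H]3[C@@H]4CC[C@@H](C4)[C@@H]3N(Cc3ccccc3F)C1=O)N2`: 83%

In an ADME assay on microsomes from liver (Homo sapiens) for metabolic stability, with a stated time of 60 min, tested at 1 uM (a higher number here means that more of the compound is left, a lower number that less of the compound is left), compound 3 gives 83%. That number lies within the scatter of compound 2 and beyond the scatter of compound 1, the only one of the two from which it clearly stands apart.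

Compound 4 `CS(=O)(=O)Nc1ccc2c(c1)S(=O)(=O)N=C(C1=C(O)[C@@H]3[C@@H]4CC[C@@H](C4)[C@@H]3N(Cc3ccc(F)c(F)c3F)C1=O)N2` differs from compound 3 by a single change: 2,3,4-trifluorophenyl in place of 2-fluorophenyl on a saturated chain carbon bound to an amide-type nitrogen in a ring. It has 2,3,4-trifluorophenyl in place of 2-fluorophenyl on a saturated chain carbon bound to an amide-type nitrogen in a ring.

Among the compounds with values here, the one measured step of a related kind, fluoro in place of hydrogen on an aromatic carbon, is a number 7 percentage points lower from compound 2 to compound 3 (within the scatter). Compound 1 carries the same 2,3,4-trifluorobenzyl group on a core of different spatial arrangement and gives 100%. On this evidence, no change beyond the scatter is expected, and the direction is only weakly indicated.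

The expected step is a number 5 percentage points higher from compound 3 to compound 4 (within the scatter).

Compound 4 is expected at 88%, with an estimated range from 74% to 100%.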

Compound 4, percent of the compound remaining: 87%
Compound 4: the middle estimate sits 1 percentage points above what was measured; measured number inside the range.
By their numbers in this assay, from the lowest: compounds 3, 4, 2 and 1 (each within the scatter of the next, the first and the last beyond it).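

At this position, on a saturated chain carbon bound to an amide-type nitrogen in a ring, this assay does not separate 2,3,4-trifluorophenyl from 2-fluorophenyl, with a number 4 percentage points higher from compound 3 to compound 4 (within the scatter), or from phenyl, with a number 3 percentage points lower from compound 2 to compound 4 (within the scatter). The earlier compounds had shown this for 2-fluorophenyl alone, so the more heavily fluorinated group now also stays within the scatter on the shared core. A new kind of comparison also appears, a number 13 percentage points lower from compound 1 to compound 4 (beyond the scatter), and with the same group on both sides this gap can only go with the arrangement of the core: the fact that compounds 1 and 4 differ only in the configuration as drawn.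

The compounds shown leave open whether the gap between the two arrangements also appears with any other group at this position. They also leave open how a group other than a phenyl ring, such as an amine or a carboxylic acid, would fare there.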